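The source may report more compounds than this note shows. Statements on the series, on what has been measured and on what is new or still open speak of the compounds shown alone.

Measured so far in a functional assay on MCF7 cells (Homo sapiens) for antiproliferative activity, read by MTT assay, with a stated time of 48 h, tested at 12.5 uM; a higher number here means a weaker effect of the compound at the concentration tested, a lower number a stronger effect:
compound 1 `C[C@@H](O)CCn1nc2c(Br)c(Br)c(Br)c(Br)c2n1` gives 86%;
compound 2 `C[C@H](O)CCn1nc2c(Br)c(Br)c(Br)c(Br)c2n1` gives 100%;
compound 3 `CC(O)CCn1nc2c(Br)c(Br)c(Br)c(Br)c2n1` gives 79%.

Compound 3 thus has the lowest of the three numbers. One gap is a number 7 percentage points lower from compound 1 to compound 3 (within the scatter), the other is a number 21 percentage points lower from compound 2 to compound 3 (beyond the scatter); both gaps rest on the fact that one of compounds 1 and 3 is drawn with a defined configuration and the other without, at the place where they differ and (the fact that one of compounds 2 and 3 is drawn with a defined configuration and the other without, at the place where they differ), and the gap a number 14 percentage points higher from compound 1 to compound 2 (beyond the scatter) rests on (the fact that compounds 1 and 2 differ only in the configuration as drawn).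

Compound 4 `OCC(O)Cn1nc2c(Br)c(Br)c(Br)c(Br)c2n1` differs from compound 3 by 1,2-dihydroxyethyl in place of 2-hydroxypropyl on a saturated chain carbon bound to an aromatic nitrogen. Among the compounds with values here, none of the measured steps changes the atoms of the chain, so none bears directly on this step; all three are modest at most. For compound 4 a step of a number 6 percentage points higher from compound 3 to compound 4 (within the scatter) is therefore expected, small and within the scatter, giving an estimated 85% with a range from 65% to 100%.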

Compound 4, a percentage reported as activity, at one concentration (the size of the read-out at that concentration, not a potency): 116%
Compound 4: the middle estimate sits 31 percentage points below what was measured, outside the stated range (above it).
By their numbers in this assay, from the lowest: compounds 3 and 1 (each within the scatter of the next); then compound 2; then compound 4.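

In this assay, swapping 2-hydroxypropyl for 1,2-dihydroxyethyl on a saturated chain carbon bound to an aromatic nitrogen shows that changing the atoms of the chain, not only its drawn configuration, shifts the read-out. All three comparisons point toward a weaker effect: a number 37 percentage points higher from compound 3 to compound 4 (beyond the scatter), a number 30 percentage points higher from compound 1 to compound 4 (beyond the scatter) and a number 16 percentage points higher from compound 2 to compound 4 (beyond the scatter). Nothing measured here explains why this change has such an effect. Open questions are how an amine, a carboxylic acid or a longer chain at this place would read, and how the separate configurations of compound 4 would compare.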